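The source may hold more compounds than are shown below. What is called first, only, known or untested is meant among the compounds shown, and "the series" means these compounds.

The measured compounds:
Compound 1 `Cc1cc(=O)oc2cc(OCc3cn(-c4ccccc4F)nn3)ccc12` gives > 100 ug/mL, which is a limit of the assay and not a number.
Compound 2 `Cc1cc(=O)oc2cc(OCc3cn(-c4ccc(OC(F)(F)F)cc4)nn3)ccc12` gives > 100 ug/mL, also a limit.
Compound 3 `COc1cc(-n2cc(COc3ccc4c(C)cc(=O)oc4c3)nn2)cc(OC)c1OC` gives > 100 ug/mL, also a limit.

All three were tested in an ADME assay on Huh-7 cells (Homo sapiens) for cytotoxicity, read by MTT assay, with a stated time of 72 h; a higher number here means that more compound is tolerated, a lower number that less compound is tolerated. Compound 1 stands at the edge of the tested range: its value is a limit, and the same holds for the other two, as the limit of > 100 ug/mL in this assay, at which 3 of the 3 values shown sit, shows. Within the data shown here, nothing here separates compound 1 from compound 2 or compound 3; none of them reached a measurable half-maximal cytotoxic concentration within the range tested, and no step between measured compounds can be read off.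

The next compound, compound 4 `Cc1cc(=O)oc2cc(OCc3cn(CCO)nn3)ccc12`, differs from compound 1 in one place: 2-hydroxyethyl in place of 2-fluorophenyl on an aromatic nitrogen. The rest of the structure stays as it is. Among the measured compounds shown here, because the limit of > 100 ug/mL in this assay, at which 3 of the 3 values shown sit, puts every measured compound at the same limit, there is no measured step to build on. The expectation is a step of no real size in this assay: compound 4 is expected to be tolerated much as compound 1 is, with the most likely outcome again a limit rather than a number. The estimate for compound 4 is 150 ug/mL, with a range from 60 ug/mL to 400 ug/mL. The step this implies, a step that the limit leaves unreadable from compound 1 to compound 4, is expected to lie within the scatter.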

Compound 4, half-maximal cytotoxic concentration: > 100 ug/mL
Compound 4 ended at the assay's limit (the forecaster's own chance of this, stated with the estimate: 85%); the middle value is on the limit's open side.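

Among these compounds, compound 1 and compound 4 both give values that are limits and not numbers, so no step between them can be read, because both sit at the same limit: the limit of > 100 ug/mL in this assay, at which 4 of the 4 values shown sit.

The compounds shown leave open what concentration of any of them would be needed for a half-maximal cytotoxic effect in this assay and whether 2-hydroxyethyl and 2-fluorophenyl differ there at all.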